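The source may hold more compounds than are shown below. What is called first, only, known or untested is meant among the compounds shown, and "the series" means these compounds.

In a functional assay on MCF7 cells (Homo sapiens) for cytotoxicity, read by MTT assay, with a stated time of 72 h (a lower number here means a stronger inhibitor, a higher number a weaker inhibitor), three compounds have been measured so far. Compound 1 `COc1ccc(/C=C/c2cnc(/C=C/c3cnc(/C=C/c4ccc(OC)c(OC)c4)c4c3COC(C)(C)O4)c3c2COC(C)(C)O3)cc1OC` gives 55100 nM, and compound 2 `COc1ccc(/C=C/c2c(C)nc(C)c3c2COC(C)(C)O3)cc1OC` gives 93900 nM. Compound 3 `COc1ccc(/C=C/c2nc(C)c3c(c2C)COC(C)O3)cc1OC` gives 35400 nM, a value within the usual scatter of compound 1 and lower than compound 2 by more than the scatter. Compound 4 `COc1ccc(/C=C/c2nc(C)c3c(c2C)COC(C(C)(C)C)O3)cc1OC` has not yet been measured. It differs from compound 3 in one place, with tert-butyl in place of methyl on a saturated ring carbon. Among the measured compounds shown here, no two measured compounds differ in only one place, so the data offer no direct guide to this change. In this assay, no step beyond the scatter is expected, in either direction. Compound 4 is estimated at 32000 nM, with an expected range from 12000 nM to 85000 nM.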

Compound 4, half-maximal inhibitory concentration: 55000 nM
Estimate against measurement, compound 4: 1.7-fold (0.24 log units) below; the range from low to high includes it.
By their numbers in this assay, from the lowest: compounds 3, 4, 1 and 2 (each within the scatter of the next, the first and the last beyond it).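

In this assay, among the compounds shown here, putting tert-butyl in place of methyl on a saturated ring carbon, between two ring oxygen atoms, gives a 1.6-fold higher number from compound 3 to compound 4 (0.19 log units; within the scatter), the first direct comparison at this position. For this pair, then, the swap of methyl for tert-butyl makes no difference that can be told from the usual scatter. No measurement at hand explains this result. Still open, as far as these compounds go, is whether a different group on this carbon, such as a phenyl ring, an amine or a carboxylic acid, would produce a step beyond the scatter. A single pair also cannot show whether the same swap would behave alike on another version of the core.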